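The source may hold more compounds than are shown below. What is called first, only, known or untested is meant among the compounds shown, and "the series" means these compounds.

The measured compounds:
Compound 1 `CC1CCN(C2CCN(S(=O)(=O)c3ccc(F)cc3F)CC2)CC1` gives 102 nM in a functional assay on DLD-1 cells (Homo sapiens) for antiproliferative activity, read by CellTiter-Glo, with a stated time of 72 h; on this read-out higher numbers stand for weaker inhibition and lower numbers for stronger inhibition.
Compound 2 `CC1CCN(C2CCN(S(=O)(=O)c3cccnc3Cl)CC2)CC1` reaches only a limit of the assay, > 5000 nM, in this assay.
Compound 3 `Cc1cc(C)cc(-c2cccc(S(=O)(=O)N3CCC(N4CCC(C)CC4)CC3)c2)c1` gives 41 nM in this assay.

Compound 3 stands lowest of the two numbers; compound 1 gives a higher number than compound 3, a gap beyond the usual scatter, and compound 2 sits at a limit. Within the data shown here, the one step measured between single-point neighbours is an at least 49-fold higher number from compound 1 to compound 2 (1.69 log units; beyond the scatter), a swap of the ring on the sulfonyl sulfur, where compound 2 meets (the limit of > 5000 nM in this assay, at which 1 of the 3 values shown sits). Compound 4 `Cc1cccc(S(=O)(=O)N2CCC(N3CCC(C)CC3)CC2)c1` differs from compound 3 by methyl in place of 3,5-dimethylphenyl on an aromatic carbon. This change also alters the ring that sits on the sulfonyl sulfur, and the measured step shows that alterations there can move the number greatly. Compound 4 thereby comes to resemble compound 1, which carries a single small ring at that position and gives a higher number than compound 3. Compound 4 is therefore expected to give a moderately higher number, a 3.7-fold higher number from compound 3 to compound 4 (0.56 log units; beyond the scatter). The estimate for compound 4 is 150 nM, expected between 50 nM and 500 nM.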

Compound 4, half-maximal inhibitory concentration: 25 nM
For compound 4 the middle estimate is 6.0-fold (0.78 log units) above the measured one; measured number outside the range, below it.
By their numbers in this assay, from the lowest: compounds 4 and 3 (each within the scatter of the next); then compound 1. At a limit, above all of these: compound 2.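

Replacing the 3,5-dimethylphenyl with a methyl costs nothing measurable in this assay, with a 1.6-fold lower number from compound 3 to compound 4 (0.21 log units; within the scatter), so the second aromatic ring is not needed for a low number in this series. A single ring on the sulfonyl sulfur can therefore do well, and the choice of ring matters, with a 4.1-fold lower number from compound 1 to compound 4 (0.61 log units; beyond the scatter) as 3-methylphenyl replaces 2,4-difluorophenyl. The widest step, an at least 200-fold lower number from compound 2 to compound 4 (2.30 log units; beyond the scatter), starts from a value that is a limit and not a number: the limit of > 5000 nM in this assay, at which 1 of the 4 values shown sits.

Going by these compounds, whether an amine, a carboxylic acid or a longer chain in place of the methyl would keep the number low stays open. Also open, on these data alone, is how the chlorine and the ring nitrogen of compound 2 each contribute, as these two features always appear together here.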